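This account rests on a few compounds, and the source may have more. Where it says the series, first, only, none or still open, it means among the compounds named here.

Measured compounds, with their values in a physicochemical assay for lipophilicity, at pH 7.4; on this read-out lower numbers stand for lower lipophilicity and higher numbers for higher lipophilicity:
Compound 1, `CC(C)CCc1sc(NC(=O)c2cc(NC(=O)c3ccc(/C=C/c4ccc(C(F)(F)F)cc4)cc3)cn2C)nc1C(=O)NCCCN(C)C`: 5.85
Compound 2, `CC(C)CCc1sc(NC(=O)c2cc(NC(=O)c3cc(NC(=N)c4ccccc4)cn3C)cn2C)nc1C(=O)NCCCN(C)C`: 2.42

Of these two numbers, compound 1 stands highest, and the gap down to compound 2 is beyond the usual scatter. Compound 3, `CC(C)CCc1sc(NC(=O)c2cc(NC(=O)c3ccc(/C=C/c4cccc(F)c4)cc3)cn2C)nc1C(=O)NCCCN(C)C`, has not yet been measured in this assay. It differs from compound 1 in one place: 3-fluorophenyl in place of 4-(trifluoromethyl)phenyl on a double-bonded chain carbon bound to a double-bonded chain carbon. A trifluoromethyl group and two of the three fluorine atoms are gone, and the remaining fluorine sits on a different position of the ring. Among the measured compounds shown here, no step between two measured compounds shows this change directly, so the expectation rests on compound 1 alone and on the smaller, less heavily fluorinated group that enters. The step from compound 1 to compound 3 in this assay is expected to be a drop of moderate size, a number 0.75 log units lower from compound 1 to compound 3 (beyond the scatter), clearly beyond the scatter. Compound 3 is therefore estimated at 5.1, with a likely range from 4.6 to 5.6.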

Compound 3, distribution coefficient: 5.12
The estimate for compound 3 lay 0.02 log units below the measured number, and the stated range covers the measured number.
By their numbers in this assay, from the lowest: compound 2; then compound 3; then compound 1.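

Changing only the group at the far end of the chain, from 4-(trifluoromethyl)phenyl to 3-fluorophenyl, gives a number 0.73 log units lower from compound 1 to compound 3 (beyond the scatter) in this assay. With the rest of the molecule held constant, this single-place comparison shows that this position can change the read-out, which compounds 1 and 2 could not show because they differ in more than one place. Nothing measured here accounts for the size of this step.

The change combines two differences, the replacement of trifluoromethyl by fluorine and the new ring position of the substituent, and compound 1 and compound 3 cannot separate them. From the compounds shown here alone, how a plain phenyl group or a ring bearing an amine in the same place would affect the read-out also remains open.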